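The compounds below may be only part of what the source reports. "The series", "measured", "known", "first", "only" and "open" are said of these compounds alone.

Measured so far in an assay on isolated protein for inhibition of Dihydrofolate reductase (Homo sapiens), using NADPH, with a stated time of 5 min; a higher number here means a weaker inhibitor, a lower number a stronger inhibitor:
compound 1, `CCc1nc(N)nc(N)c1C#CC(C)c1ccc(-c2ccc(O)cc2)cc1OC`, 136 nM
compound 2, `CCc1nc(N)nc(N)c1C#CC(C)c1ccc(-c2ccc(C)cc2)cc1OC`, 208 nM

Among the measured compounds shown here, compound 2 gives the highest of the two numbers in this assay, but its only neighbour, compound 1, sits close: a 1.5-fold higher number from compound 1 to compound 2 (0.18 log units; within the scatter). Compound 3, `CCc1nc(N)nc(N)c1C#CC(C)c1ccc(-c2ccc(C#N)cc2)cc1OC`, has not yet been measured in this assay. It differs from compound 2 in one place: cyano in place of methyl on an aromatic carbon; cut one bond further out, the change reads 4-methylphenyl to 4-cyanophenyl. For the measured compounds named here, no measured step exchanges methyl for cyano. Going by the values given here, the one step at this same aromatic carbon, a 1.5-fold higher number from compound 1 to compound 2 (0.18 log units; within the scatter), stayed within the scatter, so the position has so far tolerated a change of substituent without a clear shift. On that basis compound 3 is expected to stay near compound 2, with an estimated step of a 1.0-fold lower number from compound 2 to compound 3 (0.02 log units; within the scatter). The estimate for compound 3 in this assay is 200 nM, within a range from 80 nM to 500 nM.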

Compound 3, half-maximal inhibitory concentration: 477 nM
Estimate against measurement, compound 3: 2.4-fold (0.38 log units) below; low and high end bracket the measured number.
By their numbers in this assay, from the lowest: compounds 1 and 2 (each within the scatter of the next); then compound 3.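

In this assay, among the compounds shown here, cyano in place of methyl on this aromatic carbon gives a 2.3-fold higher number from compound 2 to compound 3 (0.36 log units; beyond the scatter) and is the first change at this position to move beyond the scatter. Measured against hydroxy, the same group gives a 3.5-fold higher number from compound 1 to compound 3 (0.54 log units; beyond the scatter) as well, so among the three substituents, cyano alone stands apart from the other two, whose own step stayed within the scatter. The position's earlier tolerance therefore does not extend to every group, though no available measurement explains this shift.

With only three groups at this carbon, the compounds shown cannot establish any trend across substituents. They leave open whether an amine, a carboxylic acid or a longer chain here would stay with hydroxy and methyl, sit with cyano, or move the number further.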